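The source may report more compounds than this note shows. Statements on the series, on what has been measured and on what is new or still open speak of the compounds shown alone.

Of the compounds shown here, two have so far been measured in an assay on isolated protein for inhibition of ribosomal protein S6 kinase alpha-5 (Homo sapiens), read by mobility shift assay, tested at 30 uM; on this read-out higher numbers stand for more inhibition at the one concentration tested (going by the name of the read-out) and lower numbers for less inhibition. Compound 1, with the structure `COc1cccc(-c2cc3[nH]nc(N)c3c(=O)[nH]2)c1`, gives 49%. Compound 2, with the structure `Nc1n[nH]c2cc(CC3CCNCC3)[nH]c(=O)c12`, gives 62%. Compound 1 therefore stands lowest of the two numbers; its nearest neighbour, compound 2, lies higher by a gap that is beyond the usual scatter of repeated measurements. Compound 1 and compound 2 differ in more than one place. Their two values show only where each stands, and no single change can be credited with the gap.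

Compound 3, with the structure `COc1cccc(-c2cc3c(c(N)nn3C)c(=O)[nH]2)c1`, has not yet been measured. It differs from compound 1 in one place: methyl in place of hydrogen on an aromatic nitrogen. The change sits on an aromatic nitrogen of a five-membered aromatic ring with 2 nitrogen, part of a fused or bridged system of two rings, two ring bonds from the ring atom that bears an amino group. Going by the values given here, no measured pair shows this change, so its effect is unknown from the data. The expectation is that the step of a number 19 percentage points lower from compound 1 to compound 3 (beyond the scatter) will lower inhibition, beyond the scatter. For compound 3 an inhibition of about 30% is estimated, within a range from 10% to 55%.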

Compound 3, a percentage reported as inhibition, at one concentration (the size of the read-out at that concentration, not a potency): 2%
The estimate for compound 3 lay 28 percentage points above the measured number; the measured number lies below the stated range.
By their numbers in this assay, from the lowest: compound 3; then compound 1; then compound 2.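

Going by these compounds alone, replacing hydrogen with methyl on this aromatic nitrogen is the first single change that can be read on its own in this assay, and it gives a number 47 percentage points lower from compound 1 to compound 3 (beyond the scatter). Compound 1 and compound 2 differ in more than one place and could not show this, whereas here one added carbon at one position, with the rest of the molecule unchanged, leaves compound 3 at 2% in this assay, so this nitrogen is a position where even a small change can matter greatly. Nothing available explains the drop.

As far as these compounds go, one methyl cannot separate the loss of the hydrogen from the arrival of the new group, so it remains open whether an ethyl group, a longer chain or a chain ending in an amine on this nitrogen would behave in the same way. From the compounds shown here alone, it also remains open whether the same methyl would cause a similar step on compound 2, which carries a different group elsewhere on the shared core.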